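Amino added to a coumarin-linked furoxan sulfone

A few compounds are considered here, and "the series" means these few. Any claim that something is new, unique, unknown or untested is made for them only; others in the source may bear on it.

Of the compounds shown here, three have been measured in a functional assay on HepG2 cells (Homo sapiens) for inhibition, read by MTT assay, with a stated time of 48 h; a lower number here means a stronger inhibitor, a higher number a weaker inhibitor. Compound 1 `COc1cc2ccc(=O)oc2cc1OCCCOc1no[n+]([O-])c1S(=O)(=O)c1ccccc1` gives 2900 nM. Compound 2 `COc1cc2ccc(=O)oc2cc1OCCCCOc1no[n+]([O-])c1S(=O)(=O)c1ccccc1` gives 3250 nM. Compound 3 `COc1cc2cc(N)c(=O)oc2cc1OCCOc1no[n+]([O-])c1S(=O)(=O)c1ccccc1` gives 3060 nM. Compound 2 has the highest of the three numbers, but its nearest neighbour compound 3 and its furthest neighbour compound 1 both lie within the usual scatter of it, so the three are not distinguishable on these data.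

Compound 4 `COc1cc2cc(N)c(=O)oc2cc1OCCCCOc1no[n+]([O-])c1S(=O)(=O)c1ccccc1` is not yet measured. It differs from compound 2 in one place: amino in place of hydrogen on an aromatic carbon, on an aromatic carbon of a six-membered aromatic ring with one oxygen, part of a fused system of two rings, ortho to a group of one heavy atom, two atoms from the ring oxygen, meta and para to a fused ring. Going by the values given here, no measured pair shows this change alone. Because compound 3, which carries the same amino group, gives 3060 nM, and compound 2 gives 3250 nM, the amino group is expected to shift this assay by no more than the scatter, so the step from compound 2 to compound 4 is estimated at a 1.0-fold lower number from compound 2 to compound 4 (0.02 log units; within the scatter). Compound 4 is therefore expected to give about 3100 nM, with a range from 1500 nM to 6500 nM.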

Compound 4, half-maximal inhibitory concentration: 2640 nM
Estimate against measurement, compound 4: 1.2-fold (0.07 log units) above, and the stated range covers the measured number.
By their numbers in this assay, from the lowest: compounds 4, 1, 3 and 2 (each within the scatter of the next).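

Amino in place of hydrogen on an aromatic carbon, two atoms from the ring oxygen, is now seen alone for the first time: in this assay, the change gives a 1.2-fold lower number from compound 2 to compound 4 (0.09 log units; within the scatter). The earlier compounds shown here could not show this, as none of them formed a pair differing only in this group. With the rest of compound 2 held fixed, this position therefore accepts the amino group without a change that can be told apart from repeat measurements, and no data here bear on what lies behind that result.

The compounds shown leave open whether a methoxy group, an acetamide or a carboxylic acid on this same carbon would move the number beyond the scatter. They also leave open whether a longer chain would alter the outcome of the amino change.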